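Carboxylic acid moved from a chain onto a phenyl ring

This account rests on a few compounds, and the source may have more. Where it says the series, first, only, none or still open, it means among the compounds named here.

Compound 3 `CCCCCCCCc1ccc(OCC(=O)Cn2nnc(CCC(=O)O)n2)cc1` holds the second highest of the three numbers in an assay on microsomes from brain for inhibition of Fatty-acid amide hydrolase 1 (Rattus norvegicus), read by fluorescence and HPLC, with a stated time of 60 min (a higher number here means a weaker inhibitor, a lower number a stronger inhibitor), where compound 3 gives 30 nM. Its nearest neighbour is compound 2 `CCCCCCCCc1ccc(OCC(=O)Cn2nnc(-c3ccncc3)n2)cc1`, which in this assay gives 24 nM; the step of a 1.3-fold higher number from compound 2 to compound 3 (0.10 log units; within the scatter) lies within the scatter. Furthest away is compound 1 `CCCCCCCCc1ccc(OCC(=O)Cn2nnc(-c3ccc(S(=O)(=O)N(C)C)cc3)n2)cc1`, which gives 590 nM; the step of a 20-fold lower number from compound 1 to compound 3 (1.29 log units; beyond the scatter) is beyond the scatter, as is a 25-fold lower number from compound 1 to compound 2 (1.39 log units; beyond the scatter).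

Compound 4 `CCCCCCCCc1ccc(OCC(=O)Cn2nnc(-c3ccc(C(=O)O)cc3)n2)cc1` differs from compound 3 by 4-carboxyphenyl in place of 2-carboxyethyl on an aromatic carbon. Within the data shown here, two measured steps bear on this. The step from compound 1 to compound 2 shows that a six-membered aromatic ring at this position can go with a low number, and the step from compound 2 to compound 3 shows that a carboxylic acid on a chain gives a number within the scatter of compound 2; only the 4-(dimethylsulfamoyl)phenyl of compound 1 gives a high number. Among the measured compounds shown here, no measured compound carries the acid on the ring itself, so the nearest analogy is compound 2. The expected step of a 1.3-fold higher number from compound 3 to compound 4 (0.12 log units; within the scatter) is therefore small, with no change beyond the scatter anticipated, though the range is widened by the absence of a direct precedent. For compound 4 the estimate in this assay is 40 nM, range 12 nM to 130 nM.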

Compound 4, half-maximal inhibitory concentration: 90 nM
Estimate against measurement, compound 4: 2.3-fold (0.35 log units) below; measured number inside the range.
By their numbers in this assay, from the lowest: compounds 2 and 3 (each within the scatter of the next); then compound 4; then compound 1.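

In this assay, the carboxylic acid does not carry over unchanged from chain to ring: 4-carboxyphenyl and 2-carboxyethyl are not equivalent on this aromatic carbon (a 3.0-fold higher number from compound 3 to compound 4 (0.48 log units; beyond the scatter)). The group carried by the phenyl ring also matters, as carboxy in place of dimethylsulfamoyl recovers part of the potency (a 6.6-fold lower number from compound 1 to compound 4 (0.82 log units; beyond the scatter)), yet 4-carboxyphenyl still falls short of pyridin-4-yl (a 3.8-fold higher number from compound 2 to compound 4 (0.57 log units; beyond the scatter)). No measurement shown accounts for these differences.

The compounds shown do not separate the contribution of the phenyl ring from that of the acid on it, which an unsubstituted phenyl would address. As far as these compounds go, a longer chain ending in a carboxylic acid, or a primary amide in place of the acid on the ring, also remains open.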